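The source may report more compounds than this note shows. Statements on the series, on what has been measured and on what is new or still open speak of the compounds shown alone.

Working notes on the series. Compound 1 `CC(=O)OC(C)n1cnc2c(Cl)nc(N)nc21` gives in a functional assay on CCRF-CEM cells (Homo sapiens) for inhibition (on this read-out lower numbers stand for stronger inhibition and higher numbers for weaker inhibition), only a limit and no number, > 500000 nM. Compound 2 `CC(O)n1cnc2c(Cl)nc(I)nc21` likewise reaches only a limit in this assay, > 500000 nM. Compound 3 `COc1nc(I)nc2c1ncn2OCCO` also sits at a limit there, > 500000 nM. Among the compounds with values here, all three values shown thus rest at the limit of > 500000 nM in this assay, at which 3 of the 3 values shown sit, so compound 1 cannot be placed stronger or weaker than any other compound, and no step among measured compounds is available. Compound 4 `CC(=O)OC(C)n1cnc2c(Cl)nc(F)nc21` differs from compound 1 by fluoro in place of amino on an aromatic carbon. Within the data shown here, with no measured step to lean on, the expected change in this assay is a number no higher from compound 1 to compound 4 (the limit leaves the size open), none beyond the scatter, and a limit is again expected. Compound 4 is estimated at 500000 nM in this assay, with a range from 100000 nM to 2000000 nM.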

Compound 4, half-maximal inhibitory concentration: 44000 nM
Estimate against measurement, compound 4: 11-fold (1.06 log units) above, and the stated range ends above it.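

On the aromatic carbon between two ring nitrogen atoms, fluoro in place of amino gives an at least 11-fold lower number from compound 1 to compound 4 (1.05 log units; beyond the scatter) in this assay, so this position can move the read-out on the core of compound 1. Compound 4 is the only compound shown with a number rather than a limit: the limit of > 500000 nM in this assay, at which 3 of the 4 values shown sit. As far as these compounds go, the true size of the step stays unknown, since its starting point is a limit.

From the compounds shown here alone, it remains open whether fluoro itself matters or only the loss of amino. A bromo, methoxy or methylamino group at this position would separate the two.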